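Amide and urea linkers on the shared pyrazole core

This account rests on a few compounds, and the source may have more. Where it says the series, first, only, none or still open, it means among the compounds named here.

Measured so far:
compound 1, `COc1cc(-c2nn(-c3cccc(NC(=O)c4cccc(C(F)(F)F)c4)c3)cc2-c2ccncc2)ccc1Cl`: in a functional assay on NCI-H226 cells (Homo sapiens) for inhibition, read by sulforhodamine B assay, with a stated time of 48 h (a lower number here means that less compound is tolerated, a higher number that more compound is tolerated), compound 1 gives > 50000 nM, which is a limit of the assay and not a number.
compound 2, `COc1cc(-c2nn(-c3cccc(NC(=O)Nc4cccc(C(F)(F)F)c4)c3)cc2-c2ccncc2)ccc1Cl`: in this assay compound 2 gives > 50000 nM, again a limit of the assay.

Going by the values given here, compound 2 therefore stands only at a limit, and the one further value is a limit as well, both at the same point, (the limit of > 50000 nM in this assay, at which 2 of the 2 values shown sit). Among the compounds with values here, the single measured step, a step that the two limits leave unreadable from compound 1 to compound 2, is unreadable, as both ends are limits; its size cannot be told.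

Compound 3, `COc1cc(-c2nn(-c3cccc(NC(=O)c4ccc(Cl)c(C(F)(F)F)c4)c3)cc2-c2ccncc2)ccc1Cl`, differs from compound 2 by 4-chloro-3-(trifluoromethyl)phenyl in place of (3-(trifluoromethyl)phenyl)amino on a carbonyl carbon. Within the data shown here, of the measured steps, only the one from compound 1 to compound 2 touches this part of the molecule, and it shows nothing readable, so no direction can be taken from it. Both values in the series sit at the limit, so no shift is expected beyond the scatter in this assay; the step of a number no higher from compound 2 to compound 3 (the limit leaves the size open) is estimated as essentially flat.

For compound 3 the estimate in this assay is 50000 nM, with a range from 15000 nM to 150000 nM, most likely reported again as a limit.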

Compound 3, concentration lethal to 50% of the cells: > 32500 nM
Compound 3: only a limit was reported (the forecaster's own chance of this, stated with the estimate: 75%); the middle value does not contradict the limit.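

In this assay compound 3 gives > 32500 nM, which is a limit of the assay and not a number. Going by these compounds alone, no step among compound 1, compound 2 and compound 3 can be read: all three values are limits. The compounds shown leave open the direction and size of the effect of the linker change and of the added chloro in this assay.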